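A few compounds are considered here, and "the series" means these few. Any claim that something is new, unique, unknown or untested is made for them only; others in the source may bear on it.

Compound 2 `COc1cc(OC)c2c(=O)cc(-c3ccc(OCc4cn(-c5ccc(F)cc5Cl)nn4)c(OC)c3)oc2c1` gives only a limit in an ADME assay on Huh-7 cells (Homo sapiens) for cytotoxicity, read by MTT assay, with a stated time of 72 h; on this read-out lower numbers stand for higher toxicity in this test and higher numbers for lower toxicity in this test: compound 2 reads > 100 ug/mL. The related compound 1 `COc1cc(OC)c2c(=O)cc(-c3ccc(OCc4cn(-c5ccc(Cl)cc5)nn4)c(OC)c3)oc2c1` also gives a limit in this assay: compound 1 reads > 100 ug/mL. The step that the two limits leave unreadable from compound 1 to compound 2 therefore cannot be read, because both values sit at the limit of > 100 ug/mL in this assay, at which 2 of the 2 values shown sit. Compound 3 `COc1cc(OC)c2c(=O)cc(-c3ccc(OCc4cn(-c5ccccc5Cl)nn4)c(OC)c3)oc2c1` differs from compound 2 by hydrogen in place of fluoro on an aromatic carbon. With both measured compounds at the limit, no step beyond the scatter is expected, and the estimated step that the limit leaves unreadable from compound 2 to compound 3 is small. Compound 3 is thus expected to give 150 ug/mL, within 60 ug/mL to 400 ug/mL.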

Compound 3, half-maximal cytotoxic concentration: > 100 ug/mL
Compound 3 ended at the assay's limit (the forecaster's own chance of this, stated with the estimate: 85%); the middle value does not contradict the limit.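

For the compounds shown here, no step among compound 1, compound 2 and compound 3 can be read, because all three values are limits rather than numbers: the limit of > 100 ug/mL in this assay, at which 3 of the 3 values shown sit. Going by these compounds, whether the fluoro group or the place of the chloro group affects the result in this assay stays open.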